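Trading the Aryl Group for a Flexible Phenylethyl Tether

A few compounds are considered here, and "the series" means these few. Any claim that something is new, unique, unknown or untested is made for them only; others in the source may bear on it.

For the measured compounds named here, compound 1 `Cc1cc(-c2nc(C(F)(F)F)ccc2CNC(=O)C(C)c2ccc(NS(C)(=O)=O)c(F)c2)ccc1F` stands at the lower of the two numbers so far in an assay on CHO cells for antagonist activity at transient receptor potential cation channel subfamily V member 1 (Homo sapiens), read by FLIPR (a lower number here means a stronger inhibitor, a higher number a weaker inhibitor), giving 0.4 nM, yet its only neighbour, compound 2, lies within the scatter of it. Compound 2 `CC(C(=O)NCc1ccc(C(F)(F)F)nc1C#Cc1ccccc1)c1ccc(NS(C)(=O)=O)c(F)c1` gives 0.8 nM; the step of a 2.0-fold higher number from compound 1 to compound 2 (0.30 log units; within the scatter) shows that replacing the aryl group with a phenylethynyl keeps the number within the usual scatter. Compound 3 `Cc1ccc(CCc2nc(C(F)(F)F)ccc2CNC(=O)C(C)c2ccc(NS(C)(=O)=O)c(F)c2)cc1` departs from compound 1 differently: 2-(4-methylphenyl)ethyl in place of 4-fluoro-3-methylphenyl on an aromatic carbon. This is a larger change than the step to compound 2, so a modest rise is expected, a 3.8-fold higher number from compound 1 to compound 3 (0.57 log units; beyond the scatter). Compound 3 is estimated at 1.5 nM, within 0.4 nM to 6 nM.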

Compound 3, inhibition constant: 0.6 nM
Estimate against measurement, compound 3: 2.5-fold (0.40 log units) above; the measured number falls inside the stated range.
By their numbers in this assay, from the lowest: compounds 1, 3 and 2 (each within the scatter of the next).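

In this assay putting 2-(4-methylphenyl)ethyl next to the ring nitrogen gives a 1.5-fold higher number from compound 1 to compound 3 (0.18 log units; within the scatter) while the same group set against 2-phenylethynyl gives a 1.3-fold lower number from compound 2 to compound 3 (0.12 log units; within the scatter) and neither step can be told from scatter. So this position accepts an aryl group, a phenylethynyl or a phenylethyl tether alike in these three compounds, even though the new group carries no fluorine. On these data alone, whether a ring is needed here at all stays open, and an amine or a plain butyl chain at this carbon would test that. Nothing measured here explains why these groups match.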